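This account rests on a few compounds, and the source may have more. Where it says the series, first, only, none or still open, it means among the compounds named here.

Compound 1 `O=C(C[C@H]1CC[C@]2(CC1)OO[C@]1(O2)C2CC3CC(C2)CC1C3)N1CCNCC1` with 37%
Compound 2 `O=C(C[C@H]1CC[C@]2(CC1)OO[C@]1(O2)C2CC3CC(C2)CC1C3)N1CCC(O)CC1` with 5%

In an in vivo ADME assay on the whole organism (strain Sprague-Dawley) for pharmacokinetics, with Rattus norvegicus as the target (a higher number here means that a larger share of the oral dose reaches the circulation, a lower number that a smaller share of the oral dose reaches the circulation), compound 2 stands lowest of the two measured compounds, with compound 1 as its nearest neighbour. Compound 3 `NC1CCN(C(=O)C[C@H]2CC[C@]3(CC2)OO[C@]2(O3)C3CC4CC(C3)CC2C4)CC1` differs from compound 2 by one change (amino in place of hydroxy on a saturated ring carbon). For the measured compounds named here, the one measured step that bears on this is a number 32 percentage points lower from compound 1 to compound 2 (beyond the scatter) for 4-hydroxypiperidin-1-yl in place of piperazin-1-yl, a large step beyond the scatter. That step does not test the amino group directly. However, the change puts nitrogen where compound 2 has oxygen, and compound 1 at 37% carries nitrogen in its piperazin-1-yl group. A rise of moderate to large size is therefore expected in this assay as a partial return toward compound 1. The expected change is a number 20 percentage points higher from compound 2 to compound 3 (beyond the scatter) in this estimate. Compound 3 is estimated at 25% within a range from 8% to 48% as its likely span.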

Compound 3, oral bioavailability: 78%
The estimate for compound 3 lay 53 percentage points below the measured number, and the stated range ends below it.
By their numbers in this assay, from the lowest: compound 2; then compound 1; then compound 3.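

In this assay, the exchange on the saturated ring carbon, three ring bonds from the ring nitrogen, proves to carry a large effect by itself: amino in place of hydroxy gives a number 73 percentage points higher from compound 2 to compound 3 (beyond the scatter), although both groups are counted alike for heavy atoms, hydrogen-bond donors, hydrogen-bond acceptors and net charge. The 4-aminopiperidin-1-yl group also differs from piperazin-1-yl on the carbonyl carbon, with a number 41 percentage points higher from compound 1 to compound 3 (beyond the scatter), so compound 1 no longer marks the top of the series. No measurement at hand accounts for either step.

Going by these compounds, whether the amino group itself is needed for this result stays open, since a methylamino, dimethylamino or aminomethyl group on the same ring carbon would test how far the change can be extended. A carboxylic acid at that place would show how a different group compares there.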